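The source may report more compounds than this note shows. Statements on the series, on what has been measured and on what is new or still open speak of the compounds shown alone.

Working notes on the cyanophenyl ether series, read in a functional assay on NIH3T3 cells (Mus musculus); on this read-out higher numbers stand for an effect only at larger amounts of compound and lower numbers for an effect already at smaller amounts.

Compound 1 `CCC/C=C/C=C/c1cc(C#N)ccc1COC(c1ccc(C#N)cc1)c1cncn1C` gives 16.7 nM. Compound 2 `Cn1cncc1C(OCc1ccc(C#N)cc1C#CC1(O)CCCCC1)c1ccc(C#N)cc1` gives 1.93 nM, the lowest of the two numbers in hand; the step is an 8.7-fold lower number from compound 1 to compound 2 (0.94 log units; beyond the scatter). For compound 3 `CCCCCCC#Cc1cc(C#N)ccc1COC(c1ccc(C#N)cc1)c1cncn1C` only a limit is reported, > 0.1 nM. Both steps leading to compound 3 stay unreadable due to the limit of > 0.1 nM in this assay, at which 1 of the 3 values shown sits: a step that the limit leaves unreadable from compound 1 to compound 3 and a step that the limit leaves unreadable from compound 2 to compound 3.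

Compound 4 `Cn1cncc1C(OCc1ccc(C#N)cc1CCC(C)(C)C)c1ccc(C#N)cc1` is the next member. Change from compound 2: 3,3-dimethylbutyl in place of 2-(1-hydroxycyclohexyl)ethynyl on an aromatic carbon. The hydroxyl, the ring and the triple bond all leave, and a short saturated branched chain takes their place on the aromatic carbon.

For the measured compounds named here, two measured steps bear on this. The step of an 8.7-fold lower number from compound 1 to compound 2 (0.94 log units; beyond the scatter) shows that moving from a plain hydrocarbon chain to the hydroxylated ring on the alkyne lowers the number by a modest amount; compound 4 goes the other way, back toward a hydrocarbon chain without hydroxyl. The step that the limit leaves unreadable from compound 2 to compound 3, which removes the same hydroxyl and ring, is not readable and gives no guidance. The expectation is therefore a move of roughly the reverse size, a 5.2-fold higher number from compound 2 to compound 4 (0.71 log units; beyond the scatter), toward a higher number, landing near where compound 1 sits. Compound 4 is estimated at 10 nM, with a range from 3 nM to 35 nM.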

Compound 4, half-maximal effective concentration: 0.54 nM
Compound 4: middle estimate off by 19-fold (1.27 log units), on the high side, outside the stated range (below it).
By their numbers in this assay, from the lowest: compound 4; then compound 2; then compound 1.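

In this assay, the aromatic carbon meta to a cyano group accepts a saturated chain with no ring and with no hydrogen-bond donor or acceptor: 3,3-dimethylbutyl gives a 3.6-fold lower number from compound 2 to compound 4 (0.55 log units; beyond the scatter) and a 31-fold lower number from compound 1 to compound 4 (1.49 log units; beyond the scatter). Among the compounds shown, a low number at this position therefore does not require the hydroxyl, the ring or the triple bond of 2-(1-hydroxycyclohexyl)ethynyl, so the earlier step to compound 2 cannot be read as showing that these features are needed. Compound 3 stands only as a limit, and every step involving it, including the one to compound 4, cannot be read: the limit of > 0.1 nM in this assay, at which 1 of the 4 values shown sits.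

The compounds shown do not separate the branching of 3,3-dimethylbutyl from the saturation or the length of the chain, so the reading of a straight pentyl chain at this carbon stays open. Also open, going by these compounds, is how the saturated 2-(1-hydroxycyclohexyl)ethyl group, or a short chain ending in an amine or a carboxylic acid, would read at the same place on the shared core.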